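The source may report more compounds than this note shows. Statements on the series, on what has been measured and on what is new or still open speak of the compounds shown alone.

Measured compounds and their values:
- `Cc1ccc(C(=O)N[C@@H]2[C@@H](O)[C@H](n3cnc4c(NC5CCCC5)ncnc43)O[C@@H]2C)cc1C`: compound 1, 236 nM
- `C[C@H]1O[C@@H](n2cnc3c(NC4CCCC4)ncnc32)[C@H](O)[C@H]1NC(=O)CCCc1cccs1`: compound 2, 55 nM
- `C[C@H]1O[C@@H](n2cnc3c(NC4CCCC4)ncnc32)[C@H](O)[C@H]1NC(=O)C1CCCC[C@H]1C(=O)c1cccs1`: compound 3, 98 nM

In an assay on isolated protein for binding affinity to adenosine receptor A1 (Rattus norvegicus), in the absence of a further agent (on this read-out higher numbers stand for weaker inhibition and lower numbers for stronger inhibition), compound 1 gives 236 nM, the highest of the three numbers. Compound 3 sits nearest with 98 nM, and compound 2 furthest with 55 nM; both gaps lie beyond the usual scatter.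

Compound 4 is `C[C@H]1O[C@@H](n2cnc3c(NC4CCCC4)ncnc32)[C@H](O)[C@H]1NC(=O)C1(c2ccccc2)CCCC1`. It differs from compound 1 in one place: 1-phenylcyclopentyl in place of 3,4-dimethylphenyl on a carbonyl carbon. The shared core and the amide linkage stay as they are.

Among the measured compounds shown here, the one measured step that bears on this is a 4.3-fold lower number from compound 1 to compound 2 (0.63 log units; beyond the scatter), where a non-aromatic chain took the place of the same 3,4-dimethylphenyl on the carbonyl carbon and the number went down. Compound 3, whose carbonyl carbon also carries a non-aromatic ring, gives a lower number than compound 1 as well. In compound 4 the carbonyl carbon again carries a non-aromatic ring, though one that still bears a phenyl, so a drop of modest size in this assay is expected, not a large one, and a result within the scatter of compound 1 cannot be ruled out.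

On that basis compound 4 is estimated to give 120 nM, between 40 nM and 400 nM, which would mean an expected step of a 2.0-fold lower number from compound 1 to compound 4 (0.29 log units; within the scatter).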

Compound 4, inhibition constant: 138 nM
Compound 4: middle estimate off by 1.2-fold (0.06 log units), on the low side, and the stated range covers the measured number.
By their numbers in this assay, from the lowest: compounds 2, 3, 4 and 1 (each within the scatter of the next, the first and the last beyond it).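

In this assay, putting 1-phenylcyclopentyl in place of 3,4-dimethylphenyl on the carbonyl carbon gives a 1.7-fold lower number from compound 1 to compound 4 (0.23 log units; within the scatter), so a group that adds a five-membered non-aromatic ring to the six-membered aromatic ring leaves the number within the usual scatter of compound 1. Set against 3-(thiophen-2-yl)propyl at the same place, the same group gives a 2.5-fold higher number from compound 2 to compound 4 (0.40 log units; beyond the scatter), a step beyond the scatter, so the choice of group on this carbonyl carbon can still move the number even though the first change did not clearly do so. Nothing measured here on these compounds explains either step, so the reason for the difference stays unknown.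

The compounds shown leave open what each part of 1-phenylcyclopentyl contributes, and a plain cyclopentyl on the carbonyl carbon, without the phenyl, would help separate the ring from the phenyl. They also leave open whether the thiophene of compound 2 matters or the chain alone does, which a propyl chain carrying phenyl instead of thiophene, or a longer chain, would begin to address.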